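A fluorinated ring replaces the methoxy ring of compound 2

The compounds below may be only part of what the source reports. "The series", "measured", "known", "first", "only" and "open" are said of these compounds alone.

Compound 2 `COc1ccc(/C=N/Nc2ncc3c(n2)n(C2CCCC2)c(=O)c(=O)n3C)c(OC)c1` stands at the limit of > 100000 nM in this assay, at which 1 of the 2 values shown sits. In a functional assay on PC-3 cells (Homo sapiens) for antiproliferative activity, read by MTT assay (on this read-out lower numbers stand for stronger inhibition and higher numbers for weaker inhibition), compound 2 gives only the limit > 100000 nM. Its nearest measured relative, compound 1 `Cc1cccc(/C=N/Nc2ncc3c(n2)n(C2CCCC2)c(=O)c(=O)n3C)c1`, gives 53600 nM in this assay, and the step of an at least 1.8-fold higher number from compound 1 to compound 2 (0.27 log units; that floor lies within the scatter) is the only measured one. Within the data shown here, compound 3 `Cn1c(=O)c(=O)n(C2CCCC2)c2nc(N/N=C/c3ccc(F)cc3F)ncc21` carries a change that no measured step matches: 2,4-difluorophenyl in place of 2,4-dimethoxyphenyl on a carbon with a double bond to nitrogen. With compound 2 at a limit and compound 1 near it, the chemist expects no step beyond the scatter. She expects compound 3 to give 70000 nM, within 25000 nM to 200000 nM. That amounts to an expected step of an at least 1.4-fold lower number from compound 2 to compound 3 (0.15 log units; that floor lies within the scatter).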

Compound 3, half-maximal inhibitory concentration: 13200 nM
Compound 3: the middle estimate sits 5.3-fold (0.72 log units) above what was measured; measured number below the stated range.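

In this assay, this position proves able to move the number beyond the scatter: 2,4-difluorophenyl gives an at least 7.5-fold lower number from compound 2 to compound 3 (0.87 log units; beyond the scatter) and a 4.1-fold lower number from compound 1 to compound 3 (0.61 log units; beyond the scatter). The first of these steps is only a floor, as compound 2 is read as a limit of the assay: the limit of > 100000 nM in this assay, at which 1 of the 3 values shown sits. Compound 3 is the strongest of the three compounds, a ranking that the earlier pair could not establish.

On these data alone, whether the fluorines or the loss of the methoxy groups matters more stays open, as does how a plain phenyl or a pyridine ring would read at this position.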